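The source may hold more compounds than are shown below. What is called first, only, known or untested is meant among the compounds shown, and "the series" means these compounds.

The measured compounds:
Compound 1 `O=C(COc1ccc2oc(-c3ccccc3)cc(=O)c2c1)Nc1ccc(F)cc1` — in a functional assay on NPC-TW01 cells (Homo sapiens) for antiproliferative activity, read by MTT assay, with a stated time of 72 h (a higher number here means a weaker inhibitor of growth, a lower number a stronger inhibitor of growth), compound 1 gives 740 nM.
Compound 2 `O=C(COc1ccc2c(=O)cc(-c3ccccc3)oc2c1)Nc1ccc(F)cc1` — in this assay compound 2 reaches only a limit, > 10000 nM.
Compound 3 `O=C(COc1ccc2c(=O)c(-c3ccccc3)coc2c1)Nc1ccccc1` — in this assay compound 3 likewise reaches only a limit, > 10000 nM.

Compound 3 thus stands not at a number but at a limit of this assay, and it shares that position with one other compound, as the limit of > 10000 nM in this assay, at which 2 of the 3 values shown sit, shows. Compound 1 is the only one of the three with a numeric reading, and its core differs from that of compound 3, so the two say nothing about a single change.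

Compound 4 `O=C(COc1ccc2c(=O)c(-c3ccccc3)coc2c1)Nc1ccc(-c2ccccc2)cc1` differs from compound 3 by phenyl in place of hydrogen on an aromatic carbon. Within the data shown here, no step of a single change has been measured here, so the size of the change in this assay cannot be read off any pair. With compound 3 already at a limit, the expected step of an at least 1.1-fold lower number from compound 3 to compound 4 (0.04 log units; that floor lies within the scatter) is taken as none beyond the scatter, and compound 4 is estimated at 9000 nM, within 1500 nM to 40000 nM.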

Compound 4, concentration for 50% growth inhibition: 1750 nM
Estimate against measurement, compound 4: 5.1-fold (0.71 log units) above; measured number inside the range.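

In this assay, among these compounds, the phenyl in place of hydrogen on an aromatic carbon, para to a large group, is the first single change that can be read, and it gives an at least 5.7-fold lower number from compound 3 to compound 4 (0.75 log units; beyond the scatter). This position is therefore one where a change moves the reading off the limit, and the core of compound 3 now has a numeric reading in compound 4. The true size of the step stays a floor, not a measured difference, because compound 3 has only a limit: the limit of > 10000 nM in this assay, at which 2 of the 4 values shown sit.

From the compounds shown here alone, whether this shift belongs to phenyl itself, or would also come with a methyl group, an amine or a carboxylic acid at this place, stays open. Whether phenyl would act likewise on the core of compound 1 also cannot be told from these compounds.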